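Moving the carboxyl on the phenoxy end of compound 1

The source may hold more compounds than are shown below. What is called first, only, known or untested is meant among the compounds shown, and "the series" means these compounds.

Compound 1 `Cc1c(OCCCCOc2ccccc2C(=O)O)ccc(C(=O)CC2CCCC2)c1C` gives 28% in an assay on HEK293 cells for positive allosteric modulation of metabotropic glutamate receptor 3 (Rattus norvegicus), read by thallium flux, with a stated time of 2.5 min (on this read-out lower numbers stand for smaller maximal responses and higher numbers for larger maximal responses), the lowest of the three numbers in hand, though both neighbours sit within the scatter of it: compound 2 `Cc1c(OCCCCOc2ccccc2C(=O)O)ccc(C(=O)CC2CCCC2)c1O` gives 32.9% and compound 3 `Cc1c(OCCCCOc2ccccc2C(=O)O)ccc(C(=O)CC(C)C)c1C` gives 30.7%. The two measured steps, a number 4.9 percentage points higher from compound 1 to compound 2 (within the scatter) and a number 2.7 percentage points higher from compound 1 to compound 3 (within the scatter), alter an aromatic carbon of the shared core and the saturated chain carbon bound to the carbonyl carbon, not the carboxyphenoxy end, and neither reaches beyond the scatter. Compound 4 `Cc1c(OCCCCOc2cccc(C(=O)O)c2)ccc(C(=O)CC2CCCC2)c1C` differs from compound 1 only at that end: 3-carboxyphenyl in place of 2-carboxyphenyl on an oxygen on a saturated carbon. Going by the values given here, no measured step touches this part of the series, so the expected step is no change at the digits printed from compound 1 to compound 4 (within the scatter), nothing beyond the scatter. Compound 4 is therefore estimated at 28%, within 14% to 44%.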

Compound 4, largest response reached (reported as percent of maximum), in percent of the reference or control that the assay uses: 16.5%
Compound 4: the middle estimate sits 11.5 percentage points above what was measured; measured number inside the range.
By their numbers in this assay, from the lowest: compound 4; then compounds 1, 3 and 2 (each within the scatter of the next).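

Going by these compounds alone, the carboxyphenyl end is the only place so far where a single change reaches beyond the scatter: 3-carboxyphenyl in place of 2-carboxyphenyl gives a number 11.5 percentage points lower from compound 1 to compound 4 (beyond the scatter) in this assay. The two groups have the same atoms and the same counts, so this step separates two arrangements of one composition. Nothing available explains the lower maximal response.

As far as these compounds go, whether the step keeps its size on the cores of compound 2 and compound 3 remains open. So does the outcome with a tetrazole or a primary amide in place of the carboxylic acid.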